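Changing the Pendant Aryl Ring: An Expectation for Compound 4

The compounds below may be only part of what the source reports. "The series", "measured", "known", "first", "only" and "open" are said of these compounds alone.

Compound 1 `COc1ccc(-c2ccc3ncn(-c4cc(OC)c(OC)c(OC)c4)c3c2)cc1F`: 430 nM
Compound 2 `COc1cc(-n2cnc3ccc(-c4ccc([N+](=O)[O-])cc4)cc32)cc(OC)c1OC`: 79 nM
Compound 3 `COc1cc(-n2cnc3ccc(-c4cccc(C)c4C)cc32)cc(OC)c1OC`: 3040 nM

These three compounds were tested in a functional assay on SGC-7901 cells (Homo sapiens) for antiproliferative activity, read by MTT assay, with a stated time of 72 h; a higher number here means a weaker inhibitor, a lower number a stronger inhibitor. Compound 1 stands second highest of the three numbers: the step of a 5.4-fold lower number from compound 1 to compound 2 (0.74 log units; beyond the scatter) went to a lower number, while the step of a 7.1-fold higher number from compound 1 to compound 3 (0.85 log units; beyond the scatter) went to a higher one, both beyond the scatter and both changing the same aryl group that compound 4 also changes. Compound 4 `COc1cc(-n2cnc3ccc(-c4ccc(F)cc4)cc32)cc(OC)c1OC` has not yet been measured. It differs from compound 1 in one place: 4-fluorophenyl in place of 3-fluoro-4-methoxyphenyl on an aromatic carbon. Since the two measured steps pulled in opposite directions, no firm direction can be drawn, and a step within or only slightly beyond the scatter is expected, a 1.2-fold higher number from compound 1 to compound 4 (0.07 log units; within the scatter). Compound 4 is therefore estimated at 500 nM, within a range from 150 nM to 1600 nM.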

Compound 4, half-maximal inhibitory concentration: 3500 nM
Compound 4: middle estimate off by 7.0-fold (0.85 log units), on the low side, and the stated range ends below it.
By their numbers in this assay, from the lowest: compound 2; then compound 1; then compounds 3 and 4 (each within the scatter of the next).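

Replacing 3-fluoro-4-methoxyphenyl with 4-fluorophenyl costs activity, with an 8.1-fold higher number from compound 1 to compound 4 (0.91 log units; beyond the scatter), so a fluorine on the pendant ring does not by itself preserve the number of compound 1. Two differently substituted rings give matching results, with a 1.2-fold higher number from compound 3 to compound 4 (0.06 log units; within the scatter). Exchanging a single group at the same ring position has a far greater effect, with a 44-fold higher number from compound 2 to compound 4 (1.65 log units; beyond the scatter), showing how much the outcome at this position depends on the group present.

From the compounds shown here alone, whether an amine or a carboxylic acid in place of the nitro group would keep the low number of compound 2 remains open. No available evidence explains these differences.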